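A few compounds are considered here, and "the series" means these few. Any claim that something is new, unique, unknown or untested is made for them only; others in the source may bear on it.

Compound 1 `CC(=O)Nc1cccc2c(-c3cccc(NC(=O)c4ccc(Br)c(C)c4)c3)ccnc12` gives > 20000 nM in a functional assay on A375P cells (Homo sapiens) for antiproliferative activity, read by MTT assay, with a stated time of 48 h (a lower number here means a stronger inhibitor, a higher number a weaker inhibitor), which is a limit of the assay and not a number.
Compound 2 `CC(=O)Nc1cccc2c(-c3cccc(NC(=O)c4ccc(F)c(C(F)(F)F)c4)c3)ccnc12` gives 6800 nM in this assay.

Going by the values given here, compound 2 thus holds the only actual number in this assay; the other value shown is a limit. Among the compounds with values here, the single measured step, an at least 2.9-fold lower number from compound 1 to compound 2 (0.46 log units; beyond the scatter), runs from a limit to a number, and the only evidence about it is the limit of > 20000 nM in this assay, at which 1 of the 2 values shown sits. The unmeasured compound 3 `CC(=O)Nc1cccc2c(-c3cccc(NC(=O)c4cc5ccccc5s4)c3)ccnc12` differs from compound 2 by 1-benzothiophen-2-yl in place of 4-fluoro-3-(trifluoromethyl)phenyl on a carbonyl carbon. This change sits at the same carbonyl carbon as the measured step, yet it swaps in a fused two-ring group rather than another substituted single ring, so the earlier step is only a loose guide. It shows that variation at this position can shift potency at least modestly, with no sign of a large gain. The step from compound 2 to compound 3 is therefore expected to be small, a 1.2-fold higher number from compound 2 to compound 3 (0.07 log units; within the scatter), within the scatter. Compound 3 is estimated at 8000 nM, with a range from 2500 nM to 20000 nM.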

Compound 3, half-maximal inhibitory concentration: 9100 nM
Compound 3: middle estimate off by 1.1-fold (0.06 log units), on the low side; the measured number falls inside the stated range.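

In this assay, replacing a substituted single ring with a fused two-ring group on the carbonyl carbon gives a 1.3-fold higher number from compound 2 to compound 3 (0.13 log units; within the scatter), so 1-benzothiophen-2-yl and 4-fluoro-3-(trifluoromethyl)phenyl cannot be told apart here. Going by these compounds alone, two quite different groups at this position therefore give readings that match within the scatter, whereas the earlier compounds showed only substituted single rings. Set against the other single-ring compound, the same group gives an at least 2.1-fold lower number from compound 1 to compound 3 (0.34 log units; beyond the scatter), a step of which only the minimum size is known. Compound 1 stands at a limit of the assay, not at a number: the limit of > 20000 nM in this assay, at which 1 of the 3 values shown sits.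

On these data alone, all three compounds carry an aromatic ring on this carbonyl carbon, so how an open alkyl chain or a group bearing an amine would read remains unknown. The shared core stays the same throughout, which leaves the effect of changes elsewhere open too.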